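The source may hold more compounds than are shown below. What is called first, only, known or untested is meant among the compounds shown, and "the series" means these compounds.

Working notes on the series. For the measured compounds named here, compound 2 `Cc1cc(C)nc(NS(=O)(=O)c2ccc(/N=C/c3c(Cl)c4ccccc4oc3=O)cc2)n1` gives 20 nM in a functional assay on MCF7 cells (Homo sapiens) for cytotoxicity, read by CCK-8 assay, with a stated time of 48 h (a lower number here means a stronger inhibitor, a higher number a weaker inhibitor), the lowest of the two numbers measured so far; compound 1 `N=C(N)NS(=O)(=O)c1ccc(/N=C/c2c(Cl)c3ccccc3oc2=O)cc1` gives 58 nM in this assay, and the step of a 2.9-fold lower number from compound 1 to compound 2 (0.46 log units; beyond the scatter) is the only one in hand. Compound 3 `Cc1cc(NS(=O)(=O)c2ccc(/N=C/c3c(Cl)c4ccccc4oc3=O)cc2)no1` carries 5-methyl-1,2-oxazol-3-yl in place of 4,6-dimethylpyrimidin-2-yl on a sulfonamide nitrogen. The measured step bears on the same sulfonamide nitrogen but compares an acyclic group with a six-membered aromatic ring, whereas compound 3 exchanges one aromatic ring for another; nothing measured tells how two such rings compare at this position. An aromatic ring is kept, so a large move in either direction is not expected; a small step toward a higher number is estimated, a 1.8-fold higher number from compound 2 to compound 3 (0.24 log units; within the scatter), with the change barely beyond the scatter. Compound 3 is expected to give 35 nM in this assay, within the range 12 nM to 110 nM.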

Compound 3, half-maximal inhibitory concentration: 12 nM
Estimate against measurement, compound 3: 2.9-fold (0.46 log units) above; low and high end bracket the measured number.
By their numbers in this assay, from the lowest: compounds 3 and 2 (each within the scatter of the next); then compound 1.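

In this assay a five-membered aromatic ring on the sulfonamide nitrogen is not told apart from a six-membered one: 5-methyl-1,2-oxazol-3-yl in place of 4,6-dimethylpyrimidin-2-yl gives a 1.7-fold lower number from compound 2 to compound 3 (0.22 log units; within the scatter) and so no ranking of the two rings. The comparison with the acyclic group now rests on two steps, a 2.9-fold lower number from compound 1 to compound 2 (0.46 log units; beyond the scatter) and a 4.8-fold lower number from compound 1 to compound 3 (0.68 log units; beyond the scatter), and among these three compounds, with none going against it, an aromatic ring of either size on this nitrogen goes with the lower number. Nothing at hand gives a reason for these numbers.

The compounds shown leave open how a phenyl ring with no hetero atoms would compare on this nitrogen. They also leave open what a plain methyl group or a morpholine ring would give there.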